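A few compounds are considered here, and "the series" means these few. Any claim that something is new, unique, unknown or untested is made for them only; others in the source may bear on it.

Measured so far in a functional assay on HBL-100 cells (Homo sapiens) for antiproliferative activity, read by sulforhodamine B assay, with a stated time of 48 h; on this read-out lower numbers stand for stronger inhibition of growth and higher numbers for weaker inhibition of growth

- compound 1 `CCCCCC(C#CC(=O)OC)O/C=C/C(=O)OC` gives 1900 nM
- compound 2 `CCCC(C#CC(=O)OC)O/C=C/C(=O)OC` gives 270 nM

Compound 2 has the lower of these two numbers, so it is the stronger growth inhibitor of the pair. The next compound, compound 3 `COC(=O)C#CC(O/C=C/C(=O)OC)C(C)(C)C`, differs from it at one place: tert-butyl in place of propyl on a saturated chain carbon bound to an oxygen on an unsaturated carbon and a triple-bonded carbon. Going by the values given here, only one measured step bears on this change, and it is a loose guide: a 7.0-fold lower number from compound 1 to compound 2 (0.85 log units; beyond the scatter). In that step a carbon chain was cut back by ethyl and the number fell. Going from compound 2 to compound 3 adds carbon instead, in a branched group that has not yet been tested. A modest rise is therefore expected in this assay, smaller than the measured step and possibly lost in the scatter. The estimated change is a 2.0-fold higher number from compound 2 to compound 3 (0.31 log units; beyond the scatter). For compound 3 the expected value is 550 nM, with an estimated range from 150 nM to 2000 nM.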

Compound 3, concentration for 50% growth inhibition: 1800 nM
Compound 3: middle estimate off by 3.3-fold (0.51 log units), on the low side, within the range that was stated.
By their numbers in this assay, from the lowest: compound 2; then compounds 3 and 1 (each within the scatter of the next).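

In this assay, replacing propyl with tert-butyl on this saturated chain carbon gives a 6.7-fold higher number from compound 2 to compound 3 (0.82 log units; beyond the scatter), so a branched group loses most of the growth inhibition seen with propyl. Pentyl and tert-butyl cannot be told apart at this position, with a 1.1-fold lower number from compound 1 to compound 3 (0.02 log units; within the scatter), and thus a straight and a branched group give the same result here, with propyl the only one of the three standing out with a lower number. Nothing measured here explains why these groups differ.

The compounds shown leave open whether propyl marks a narrow best fit or whether a shorter chain such as ethyl or methyl would lower the number further. They also leave open how a smaller branched group, such as isopropyl, or a butyl chain would behave.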